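Trifluoromethyl for Methoxy: Expecting the Potency of Compound 4

The compounds below may be only part of what the source reports. "The series", "measured", "known", "first", "only" and "open" are said of these compounds alone.

Compound 1 `COc1ccc2[nH]c(-c3cn(-c4ccccc4)nc3-c3ccc(F)cc3)nc2c1` is the reference here. In a functional assay on MCF7 cells (Homo sapiens) for antiproliferative activity, read by MTT assay, with a stated time of 48 h (on this read-out lower numbers stand for stronger inhibition and higher numbers for weaker inhibition), compound 1 gives 970 nM. Compound 2 `Fc1ccc(-c2nn(-c3ccccc3)cc2-c2nc3cc(C(F)(F)F)ccc3[nH]2)cc1` carries trifluoromethyl in place of methoxy on an aromatic carbon; in this assay compound 2 gives 2130 nM, which is a 2.2-fold higher number from compound 1 to compound 2 (0.34 log units; beyond the scatter). Compound 3 `COc1ccc(-c2nn(-c3ccccc3)cc2-c2nc3cc(OC)ccc3[nH]2)cc1` differs from compound 1 by methoxy in place of fluoro on an aromatic carbon, and in this assay compound 3 gives 3130 nM, a step of a 3.2-fold higher number from compound 1 to compound 3 (0.51 log units; beyond the scatter).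

Compound 4 `COc1ccc(-c2nn(-c3ccccc3)cc2-c2nc3cc(C(F)(F)F)ccc3[nH]2)cc1` has not yet been measured. It differs from compound 3 by trifluoromethyl in place of methoxy on an aromatic carbon, the same change that was made from compound 1 to compound 2, at the same place. Since that earlier step was a 2.2-fold higher number from compound 1 to compound 2 (0.34 log units; beyond the scatter), compound 4 is expected to show a similar step, a 2.1-fold higher number from compound 3 to compound 4 (0.32 log units; beyond the scatter), on the assumption that the change behaves alike on the two cores. Compound 4 is therefore estimated at 6500 nM in this assay.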

Compound 4, half-maximal inhibitory concentration: 5730 nM
Compound 4: the middle estimate sits 1.1-fold (0.05 log units) above what was measured, within the range that was stated.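

In this assay, trifluoromethyl in place of methoxy gave a 1.8-fold higher number from compound 3 to compound 4 (0.26 log units; within the scatter), which agrees with the earlier step for this change: the same change on two cores in this assay, a 2.2-fold higher number (0.34 log units; beyond the scatter) from compound 1 to compound 2 and a 1.8-fold higher number (0.26 log units; within the scatter) from compound 3 to compound 4, 1.2-fold (0.08 log units) apart, within the scatter of two such steps. Methoxy in place of fluoro gave a 2.7-fold higher number from compound 2 to compound 4 (0.43 log units; beyond the scatter), and this also matches its earlier step: the same change on two cores in this assay, a 3.2-fold higher number (0.51 log units; beyond the scatter) from compound 1 to compound 3 and a 2.7-fold higher number (0.43 log units; beyond the scatter) from compound 2 to compound 4, 1.2-fold (0.08 log units) apart, within the scatter of two such steps. Each change therefore had a similar size on the two cores tested, but four compounds cannot show that this holds across the wider series, nor do they explain why the numbers rise.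

The compounds shown leave open how an amine or a carboxylic acid would behave on the same aromatic carbon. They also leave open whether a longer chain, such as ethoxy, would follow the methoxy results.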